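The compounds below may be only part of what the source reports. "The series", "measured", "known", "first", "only" and "open" are said of these compounds alone.

Compound 1 `Cn1ccc2ccc(-c3cc(Nc4ccccc4S(=O)(=O)NCC4CCOCC4)cc4nccnc34)cc21`: > 100000 nM
Compound 2 `Cn1cc(NC(=O)c2ccncc2Nc2cc(-c3ccc4ccn(C)c4c3)c3nccnc3c2)cn1`: 26500 nM

In an assay on lysate for inhibition of 6-phosphofructo-2-kinase/fructose-2,6-bisphosphatase 3 (Homo sapiens), with stated times of 0.5 min and 45 min (a lower number here means a stronger inhibitor, a higher number a weaker inhibitor), compound 1 gives only a limit of the assay, > 100000 nM. Among the measured compounds shown here, compound 2 gives 26500 nM, the only number among the two results. The other result is a limit (the limit of > 100000 nM in this assay, at which 1 of the 2 values shown sits). Compound 3 `CN1CCC(CNC(=O)c2ccncc2Nc2cc(-c3ccc4ccn(C)c4c3)c3nccnc3c2)C1` is not yet measured and differs from compound 2 in one place: (1-methylpyrrolidin-3-yl)methyl in place of 1-methyl-1H-pyrazol-4-yl on an amide-type nitrogen. For the measured compounds named here, no pair of measured compounds shows a step of this kind, so its size cannot be read from these data. Compound 3 is expected to land near compound 2, with an estimated step of a 1.1-fold higher number from compound 2 to compound 3 (0.05 log units; within the scatter), within the scatter. The estimate for compound 3 is 30000 nM, with a range from 8000 nM to 100000 nM.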

Compound 3, half-maximal inhibitory concentration: 24000 nM
For compound 3 the middle estimate is 1.3-fold (0.10 log units) above the measured one; low and high end bracket the measured number.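

Placing (1-methylpyrrolidin-3-yl)methyl, a five-membered non-aromatic ring with 1 hetero atom, in place of 1-methyl-1H-pyrazol-4-yl, a five-membered aromatic ring with 2 hetero atoms, on the amide-type nitrogen gives a 1.1-fold lower number from compound 2 to compound 3 (0.04 log units; within the scatter) in this assay. At this position, then, the two groups cannot be told apart, and an aromatic ring on this nitrogen is not needed to keep the reading of compound 2. Nothing measured here accounts for this result. Going by these compounds, whether a plain methyl or a longer chain ending in a carboxylic acid on this nitrogen would move the number beyond the scatter stays open.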